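Benzoyl on the aromatic nitrogen: an open step

The source may hold more compounds than are shown below. What is called first, only, known or untested is meant among the compounds shown, and "the series" means these compounds.

- compound 1 `O=C(Nc1n[nH]c2c1CN(C(=O)c1ccccc1)C2)c1ccccc1` gives 6400 nM
- compound 2 `CC(C)C(=O)n1nc(NC(=O)c2ccccc2)c2c1CN(C(=O)c1ccccc1)C2` gives 2020 nM
- compound 3 `O=C(Nc1nn(C(=O)C2CC2)c2c1CN(C(=O)c1ccccc1)C2)c1ccccc1` gives 1240 nM
- compound 4 `O=C(Nc1nn(C(=O)c2ccccc2)c2c1CN(C(=O)c1ccccc1)C2)c1ccccc1` is not yet measured

In a functional assay on HCT-116 cells (Homo sapiens) for cytotoxicity, read by sulforhodamine B assay, with a stated time of 48 h (a higher number here means a weaker inhibitor, a lower number a stronger inhibitor), compound 3 gives 1240 nM and lies within the scatter of compound 2, with compound 1 clearly higher. The change to compound 4 puts phenyl in place of cyclopropyl on a carbonyl carbon. Two measured steps replaced hydrogen on an aromatic nitrogen, and both were modest (a 3.2-fold lower number from compound 1 to compound 2 (0.50 log units; beyond the scatter); a 5.2-fold lower number from compound 1 to compound 3 (0.71 log units; beyond the scatter)). They say little here, since compound 3 already carries a group at that place. The closer guide is the change on the carbonyl carbon itself (a 1.6-fold lower number from compound 2 to compound 3 (0.21 log units; within the scatter)), which stayed within the scatter. No aromatic group has been measured at this place, so the range is kept wide. No step beyond the scatter is expected in either direction (a 1.1-fold higher number from compound 3 to compound 4 (0.05 log units; within the scatter)). Compound 4 is estimated at 1400 nM with an expected range from 550 nM to 3500 nM in this assay for now.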

Compound 4, half-maximal inhibitory concentration: 1400 nM
Compound 4: middle estimate and measured number agree at the digits printed; the range from low to high includes it.
By their numbers in this assay, from the lowest: compounds 3, 4 and 2 (each within the scatter of the next); then compound 1.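

In this assay, an aromatic ring on the carbonyl carbon reads the same as the two non-aromatic groups: phenyl in place of cyclopropyl (a 1.1-fold higher number from compound 3 to compound 4 (0.05 log units; within the scatter)) and phenyl in place of isopropyl (a 1.4-fold lower number from compound 2 to compound 4 (0.16 log units; within the scatter)) both stay within the scatter, so these three groups cannot be told apart at this place. Benzoyl in place of hydrogen on the aromatic nitrogen (a 4.6-fold lower number from compound 1 to compound 4 (0.66 log units; beyond the scatter)) extends the step beyond the scatter, seen so far only with isopropylcarbonyl and cyclopropylcarbonyl, to an aromatic acyl group, and no acylated compound shown goes against it. No measured evidence accounts for this result.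

Still open, on these data alone, is whether the flat reading holds with an amine on the carbonyl carbon, a longer chain there, or a phenyl carrying a carboxylic acid. The compounds shown also leave open whether the same reading appears in any test other than this one cell line.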